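The source may report more compounds than this note shows. Statements on the series, on what has been measured and on what is new or still open speak of the compounds shown alone.

Compound 1 `Cc1cc2[nH]nc(N)c2c(=O)[nH]1` was tested in an assay on isolated protein for inhibition of RAC-alpha serine/threonine-protein kinase (Homo sapiens), read by mobility shift assay, tested at 30 uM (on this read-out lower numbers stand for less inhibition and higher numbers for more inhibition at the one concentration tested (going by the name of the read-out)), where compound 1 gives -3%. Among the compounds with values here, compound 2 `Nc1n[nH]c2cc(CC3CCNCC3)[nH]c(=O)c12` is the only other measured compound, and in this assay compound 2 gives 13%. Within the data shown here, the single measured step, a number 16 percentage points higher from compound 1 to compound 2 (beyond the scatter), concerns a saturated chain carbon and not the part of the shared core altered here. On the numbers available, compound 1 stands as the lower of the two. The unmeasured compound 3 `Cc1cc2c(c(N)nn2C)c(=O)[nH]1` differs from compound 1 by methyl in place of hydrogen on an aromatic nitrogen. Among the measured compounds shown here, no measured step bears on a change at this aromatic nitrogen, so the data give no ground for a shift in either direction. A step of a number 3 percentage points higher from compound 1 to compound 3 (within the scatter) is therefore expected, which is to say none beyond the scatter. Compound 3 is estimated to give 0% in this assay, with a range from -12% to 12%.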

Compound 3, a percentage reported as inhibition, at one concentration (the size of the read-out at that concentration, not a potency): 11%
Estimate against measurement, compound 3: 11 percentage points below; measured number inside the range.
By their numbers in this assay, from the lowest: compound 1; then compounds 3 and 2 (each within the scatter of the next).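

In this assay, within the data shown here, methyl in place of hydrogen on an aromatic nitrogen of the five-membered aromatic ring gives a number 14 percentage points higher from compound 1 to compound 3 (beyond the scatter) and so shows that this position, which the earlier compounds left unchanged, is one where a single added carbon moves the number beyond the scatter. The change on this nitrogen thus joins the change on the saturated chain carbon as a second place where a modest rise is seen, though each rests on one pair of compounds. Nothing measured here accounts for the rise.

Going by these compounds, whether a longer chain on this aromatic nitrogen, such as ethyl or propyl, would move the number further remains open. So does whether methyl on this nitrogen and the piperidin-4-yl group of compound 2 would add up when carried on one molecule.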